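Swapping Trifluoromethoxy for Trifluoromethyl on Compound 1

The source may report more compounds than this note shows. Statements on the series, on what has been measured and on what is new or still open speak of the compounds shown alone.

Compound 1 `CCc1nc(-c2ccc(OC(F)(F)F)cc2OC)c(CC)nc1NC(CC)CC` is one of three compounds tested in an assay on IMR-32 cells for displacement of a labelled ligand from corticotropin-releasing factor receptor 1 (Homo sapiens), read by scintillation counting, with a stated time of 2 h (a higher number here means a weaker inhibitor, a lower number a stronger inhibitor), where compound 1 gives 7.2 nM. Compound 3 `CCc1nc(-c2ccc(OC(F)(F)F)cc2OC)c(OC)nc1NC(CC)CC` gives 6.1 nM, and the step of a 1.2-fold lower number from compound 1 to compound 3 (0.07 log units; within the scatter) lies within the scatter. Compound 2 `CCc1nc(NC(CC)CC)cnc1-c1ccc(Cl)cc1Cl`, built on a different core, gives 545 nM, a far higher number than compound 1, so compound 1 stands second highest of the three. Compound 4 `CCc1nc(-c2ccc(C(F)(F)F)cc2OC)c(CC)nc1NC(CC)CC` has not yet been measured; it differs from compound 1 by trifluoromethyl in place of trifluoromethoxy on an aromatic carbon. Within the data shown here, no measured step touches this group, so the only guide is the flat step just described, which suggests a small change. For compound 4 the expected step is a 1.1-fold higher number from compound 1 to compound 4 (0.05 log units; within the scatter), within the scatter. Compound 4 is estimated at 8 nM, ranging from 3 nM to 25 nM.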

Compound 4, inhibition constant: 5.6 nM
Compound 4: middle estimate off by 1.4-fold (0.15 log units), on the high side; the measured number falls inside the stated range.
By their numbers in this assay, from the lowest: compounds 4, 3 and 1 (each within the scatter of the next); then compound 2.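

In this assay, trifluoromethyl on the aromatic carbon para to a large group gives a 1.3-fold lower number from compound 1 to compound 4 (0.11 log units; within the scatter) and so adds a second flat step, this time at a new position. Trifluoromethoxy can lose its oxygen, which removes its one counted hydrogen-bond acceptor, with no change beyond the scatter. No measurement here explains this flat result.

On these data alone, both groups carry three fluorines, so it remains open whether this position would tolerate something quite different, such as an amine or a carboxylic acid. A plain hydrogen there is equally untested in the compounds shown.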